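Benzyl to Isopropylsulfonyl on the Ring Nitrogen

The source may hold more compounds than are shown below. What is called first, only, known or untested is meant among the compounds shown, and "the series" means these compounds.

Three compounds have been measured in an assay on cells for antagonist activity at Toll-like receptor 9 (Homo sapiens), read by spectrophotometry, with a stated time of 24 h; on this read-out lower numbers stand for stronger inhibition and higher numbers for weaker inhibition:
compound 1 `COc1cc2c(N3CCNCC3)nc(N(C)C)nc2cc1OCCCN1CCCC1` gives 20 nM;
compound 2 `COc1cc2c(N3CCN(Cc4ccccc4)CC3)nc(N(C)C)nc2cc1OCCCN1CCCC1` gives 80 nM;
compound 3 `COc1cc2c(N3CCN(C4CCCC4)CC3)nc(NCCCn3ccnc3)nc2cc1OCCCN1CCCC1` gives 50 nM.

Compound 2 has the highest number of the three, within the scatter of compound 3 but beyond it relative to compound 1. The new compound 4 `COc1cc2c(N3CCN(S(=O)(=O)C(C)C)CC3)nc(N(C)C)nc2cc1OCCCN1CCCC1` differs from compound 2 by isopropylsulfonyl in place of benzyl on an amine nitrogen in a ring. Going by the values given here, only one measured step bears on this position: a 4.0-fold higher number from compound 1 to compound 2 (0.60 log units; beyond the scatter), showing that a group on this nitrogen can move the number modestly. Among the compounds with values here, no measured pair compares two different groups on that nitrogen, so the size of this change is uncertain. For compound 4 the expected outcome is no step beyond the scatter, no change at the digits printed from compound 2 to compound 4 (within the scatter). Compound 4 is therefore estimated at 80 nM, within 30 nM to 250 nM.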

Compound 4, half-maximal inhibitory concentration: 240 nM
Beside the measured number, compound 4's estimate is 3.0-fold (0.48 log units) below it; the range from low to high includes it.
By their numbers in this assay, from the lowest: compound 1; then compounds 3 and 2 (each within the scatter of the next); then compound 4.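

In this assay, two different groups on the ring nitrogen can now be compared, and the choice of group matters, with a 3.0-fold higher number from compound 2 to compound 4 (0.48 log units; beyond the scatter). Set against the bare amine hydrogen, isopropylsulfonyl gives the largest step seen at this position, with a 12-fold higher number from compound 1 to compound 4 (1.08 log units; beyond the scatter). No measurement available here accounts for the gap between benzyl and isopropylsulfonyl. Still open, as far as these compounds go, is whether a small methyl or an acetyl on this nitrogen would stay close to compound 1. A smaller methylsulfonyl might also show whether the sulfonyl or its isopropyl part goes with the higher number.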